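The compounds below may be only part of what the source reports. "The series", "measured", "known", "first", "only" and "open" are said of these compounds alone.

Measured so far in an ADME assay on HEp-2 cells (Homo sapiens) for cytotoxicity, read by MTT assay, with a stated time of 3 days; on this read-out lower numbers stand for higher toxicity in this test and higher numbers for lower toxicity in this test: compound 1 `CCC[C@H](CCn1cncn1)c1ccccc1` gives 58.4 ug/mL; compound 2 `CCC[C@H](CCn1cncn1)c1ccc(OC)cc1` gives 59.6 ug/mL; compound 3 `c1ccc(C[C@@H](CCn2cncn2)c2ccccc2)cc1` gives 55.9 ug/mL.

Compound 2 arises from compound 1 by the change (methoxy in place of hydrogen on an aromatic carbon), and the step of a 1.0-fold higher number from compound 1 to compound 2 (0.01 log units; within the scatter) shows that this change left the read-out essentially unmoved. Compound 3 rests on a different core from compound 1; how the two cores differ is not broken down here, but their values in this assay lie within the scatter of each other. Compound 4 `COc1ccc([C@H](CCn2cncn2)Cc2ccccc2)cc1` arises from compound 3 by the same change, (methoxy in place of hydrogen on an aromatic carbon), made on the same kind of place. Compound 4 is therefore expected to give 57 ug/mL, within a range of 40 ug/mL to 82 ug/mL. This estimate means a step of a 1.0-fold higher number from compound 3 to compound 4 (0.01 log units; within the scatter), expected to be as small as the earlier one because a 1.0-fold higher number from compound 1 to compound 2 (0.01 log units; within the scatter) stayed within the scatter.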

Compound 4, half-maximal cytotoxic concentration: 60.3 ug/mL
Estimate against measurement, compound 4: 1.1-fold (0.02 log units) below, within the range that was stated.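

In this assay the exchange of hydrogen for methoxy on an aromatic carbon gives a 1.1-fold higher number from compound 3 to compound 4 (0.03 log units; within the scatter) and so again leaves the read-out essentially unmoved. Set beside the earlier step, the two cores respond alike: the same change on two cores in this assay, a 1.0-fold higher number (0.01 log units; within the scatter) from compound 1 to compound 2 and a 1.1-fold higher number (0.03 log units; within the scatter) from compound 3 to compound 4, 1.1-fold (0.02 log units) apart, within the scatter of two such steps. This shows that the change carries across these two cores without a visible effect on this read-out, but it does not show that the same would hold on any other core or in any other test.

The compounds shown carry only methoxy, para to a large group, on the aromatic ring. On these data alone, whether an amine, a carboxylic acid or a longer chain in that place would leave the read-out equally unmoved stays open.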